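This account rests on a few compounds, and the source may have more. Where it says the series, first, only, none or still open, it means among the compounds named here.

Working notes on the series. In a functional assay on DLD-1 cells (Homo sapiens) for antiproliferative activity, read by CellTiter-Glo, with a stated time of 72 h (a higher number here means a weaker inhibitor, a lower number a stronger inhibitor), compound 2 `Cc1cc(C)c(S(=O)(=O)N2CCC(N3CCN(C)CC3)CC2)c(C)c1` gives 1100 nM, the highest of the two numbers measured; the nearest neighbour is compound 3 `CC1CCN(C2CCN(S(=O)(=O)c3cccc(-c4ccccc4)c3)CC2)CC1` with 2 nM, a gap that lies beyond the scatter. Compound 1 `CCCC(=O)N(Cc1ccccc1)C1CCN(S(=O)(=O)c2c(C)cc(C)cc2C)CC1` reaches only the limit of this assay, > 5000 nM; (the limit of > 5000 nM in this assay, at which 1 of the 3 values shown sits). Compound 4 `Cc1cc(C)c(S(=O)(=O)N2CCC(C(=O)N3CCC(C)CC3)CC2)c(C)c1` is not yet measured. Compared with compound 2, compound 4 carries (4-methylpiperidin-1-yl)carbonyl in place of 4-methylpiperazin-1-yl on a saturated ring carbon. Among the measured compounds shown here, no measured pair shows this change. The step from compound 2 to compound 4 is expected to be a loss of potency of modest size, a 3.6-fold higher number from compound 2 to compound 4 (0.56 log units; beyond the scatter), with a real chance of reaching the limit, as compound 1 with its carbonyl-bearing substituent did at > 5000 nM. For compound 4 in this assay the estimate is 4000 nM, between 1000 nM and 15000 nM.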

Compound 4, half-maximal inhibitory concentration: > 5000 nM
Compound 4: only a limit was reported; the forecaster's own chance of this, stated with the estimate: 40%; middle value at least 1.2-fold (0.09 log units) away from the limit.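

In this assay, among the compounds shown here, (4-methylpiperidin-1-yl)carbonyl in place of 4-methylpiperazin-1-yl on a saturated ring carbon gives the first measured step at this position, an at least 4.5-fold higher number from compound 2 to compound 4 (0.65 log units; beyond the scatter). Compound 4 gives > 5000 nM, which is a limit of the assay and not a number, so the full size of the loss cannot be read. The series now has more values at this limit: the limit of > 5000 nM in this assay, at which 2 of the 4 values shown sit.

The step changes both the carbonyl and the ring, and compound 2 and compound 4 cannot separate the two. A (4-methylpiperazin-1-yl)carbonyl group at this position would leave the carbonyl's contribution open to reading on its own.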